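Removing the sugar from the triazole nitrogen of compound 1

A few compounds are considered here, and "the series" means these few. Any claim that something is new, unique, unknown or untested is made for them only; others in the source may bear on it.

Two compounds of this series have numbers in a functional assay on HCT-116 cells (Homo sapiens) for cytotoxicity, read by MTT assay, with a stated time of 72 h; a higher number here means a weaker inhibitor, a lower number a stronger inhibitor. Compound 1 `O=C1c2c[n+]([O-])c3ccccc3c2C(=O)c2c1c1ccccc1n2Cc1cn([C@H]2O[C@H](CO)[C@@H](O)[C@H]2O)nn1` gives 710 nM in this assay. Compound 2 `O=C1c2c[n+]([O-])c3ccccc3c2C(=O)c2c1c1ccccc1n2CCN1CCCCC1` gives 780 nM in this assay, and the two numbers lie within the scatter of each other, so neither compound stands apart from the other on these data.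

Compound 3 `O=C1c2c[n+]([O-])c3ccccc3c2C(=O)c2c1c1ccccc1n2Cc1cn(C[C@@H](O)CO)nn1` has not been measured. It differs from compound 1 in one place: 2,3-dihydroxypropyl in place of 3,4-dihydroxy-5-(hydroxymethyl)oxolan-2-yl on an aromatic nitrogen. Among the measured compounds shown here, no pair of measured compounds shares this change, so there is no measured step to lean on. The shared core is held in both compounds, and the change touches only the group on the aromatic nitrogen of the triazole ring. The step from compound 1 to compound 3 is expected to be small, a 1.1-fold higher number from compound 1 to compound 3 (0.05 log units; within the scatter), with no direction beyond the scatter. Compound 3 is therefore estimated at 800 nM in this assay, within a range from 300 nM to 2200 nM.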

Compound 3, half-maximal inhibitory concentration: 190 nM
Beside the measured number, compound 3's estimate is 4.2-fold (0.62 log units) above it; the whole stated range lies above it.
By their numbers in this assay, from the lowest: compound 3; then compounds 1 and 2 (each within the scatter of the next).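

In this assay, the group on the aromatic nitrogen of the five-membered aromatic ring with 3 nitrogen proves to be a position where the number can move: 2,3-dihydroxypropyl in place of 3,4-dihydroxy-5-(hydroxymethyl)oxolan-2-yl gives a 3.7-fold lower number from compound 1 to compound 3 (0.57 log units; beyond the scatter). The two earlier compounds, within the scatter of each other, could not show this. Against the (piperidin-1-yl)methyl group, 1-(2,3-dihydroxypropyl)-1H-1,2,3-triazol-4-yl gives a 4.1-fold lower number from compound 2 to compound 3 (0.61 log units; beyond the scatter), so compound 3 now stands apart from both, though no measurement at hand accounts for either step.

The compounds shown leave open whether the hydroxyl groups of the 2,3-dihydroxypropyl chain are needed, which a plain propyl chain would test, and whether its one defined stereocentre matters. Also open, from the compounds shown here alone, is how an amine or a carboxylic acid at the end of a chain on this nitrogen would compare with compound 3.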